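A few compounds are considered here, and "the series" means these few. Any claim that something is new, unique, unknown or untested is made for them only; others in the source may bear on it.

Two members of the series carry a measured value. Compound 1 `COc1cc(N2C(=O)[C@H](Oc3ccccc3)[C@H]2c2ccc(C#N)cc2)cc(OC)c1OC` gives 168000 nM in a functional assay on MCF7 cells (Homo sapiens) for antiproliferative activity, read by MTT assay, with stated times of 24 h and 72 h; a higher number here means a weaker inhibitor, a lower number a stronger inhibitor. For the measured compounds named here, compound 2 `COc1cc(N2C(=O)[C@@H](Oc3ccccc3)[C@H]2c2cccc([N+](=O)[O-])c2)cc(OC)c1OC` gives 30000 nM in this assay and so stands with the lower of the two numbers, its gap to compound 1 beyond the scatter; no step of a single change links these two, so the two values are noted as they stand. Compound 3 `COc1ccc([C@@H]2[C@H](Oc3ccccc3)C(=O)N2c2cc(OC)c(OC)c(OC)c2)cc1N` is not yet measured in this assay. The change from compound 2 to compound 3 is 3-amino-4-methoxyphenyl in place of 3-nitrophenyl on a saturated ring carbon. Going by the values given here, no measured pair shows this change, so its size is open. The step from compound 2 to compound 3 is expected as a 3.8-fold lower number from compound 2 to compound 3 (0.57 log units; beyond the scatter), toward a lower number, of a size likely beyond the scatter, though with wide uncertainty because compound 2 alone anchors it at 30000 nM. For compound 3 the expected value in this assay is 8000 nM, within a range of 800 nM to 50000 nM.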

Compound 3, half-maximal inhibitory concentration: 12200 nM
For compound 3 the middle estimate is 1.5-fold (0.18 log units) below the measured one; the range from low to high includes it.
By their numbers in this assay, from the lowest: compound 3; then compound 2; then compound 1.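

For the compounds shown here, the first single-change step falls on the saturated ring carbon next to the ring nitrogen: 3-amino-4-methoxyphenyl in place of 3-nitrophenyl gives a 2.5-fold lower number from compound 2 to compound 3 (0.39 log units; beyond the scatter) in this assay, so the number at this position moves with the aryl group, modestly but beyond the scatter. The entering group differs from the leaving one in two features at once, an amino group in place of the nitro group and an added methoxy, and this one step does not divide the shift between them. No evidence at hand bears on the reason for the shift.

Open, from the compounds shown here alone, is how 3-aminophenyl without the methoxy or 3-nitro-4-methoxyphenyl would read. Also open, going by these compounds, is whether a hydroxyl or an acetamide in place of the amino group would hold the lower number.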